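The source may report more compounds than this note shows. Statements on the series, on what has been measured and on what is new or still open speak of the compounds shown alone.

Measured so far in a physicochemical assay for solubility; a higher number here means a more soluble compound, a lower number a less soluble compound:
- compound 1 `COc1cc2cc(C(=O)CCc3cc[n+](C)cc3)sc2cc1OC`: 3000 ug/mL
- compound 2 `CCOCC[n+]1ccc(CCC(=O)c2cc3cc(OC)c(OC)cc3s2)cc1`: 50000 ug/mL

Compound 2 stands highest of the two numbers in this assay; the nearest is compound 1, reached by a 17-fold higher number from compound 1 to compound 2 (1.22 log units; beyond the scatter). Compound 3 `COc1cc2cc(C(=O)CCc3cc[n+](Cc4ccccc4)cc3)sc2cc1OC` is not yet measured. The change from compound 2 to compound 3 is phenyl in place of ethoxymethyl on a saturated chain carbon bound to an aromatic nitrogen. Within the data shown here, only one measured step bears on it, and only loosely: a 17-fold higher number from compound 1 to compound 2 (1.22 log units; beyond the scatter) shows the group on the saturated chain carbon bound to the aromatic nitrogen moves the number strongly. Among the measured compounds shown here, no measured step shows a phenyl there. For compound 3 the expected step is an 8.3-fold lower number from compound 2 to compound 3 (0.92 log units; beyond the scatter), a moderate decrease. Compound 3 is estimated at 6000 ug/mL, within 1000 ug/mL to 35000 ug/mL.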

Compound 3, solubility: 2000 ug/mL
Compound 3: middle estimate off by 3.0-fold (0.48 log units), on the high side, and the stated range covers the measured number.
By their numbers in this assay, from the lowest: compounds 3 and 1 (each within the scatter of the next); then compound 2.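

In this assay, phenyl in place of ethoxymethyl on a saturated chain carbon bound to an aromatic nitrogen gives a 25-fold lower number from compound 2 to compound 3 (1.40 log units; beyond the scatter) and so removes the earlier gain at this position. Phenyl in place of hydrogen at the same place gives a 1.5-fold lower number from compound 1 to compound 3 (0.18 log units; within the scatter) and so leaves the number within the scatter, which means that a larger group there does not by itself raise it: among these compounds, only compound 2 stands apart. No measurement on hand accounts for this difference.
Open, going by these compounds, is whether the oxygen of ethoxymethyl or the chain itself carries the step, which an all-carbon propyl group there could separate. On these data alone, how an amine or a carboxylic acid at this place would read also remains open.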